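The compounds below may be only part of what the source reports. "The series", "measured", "known", "first", "only" and "open" are said of these compounds alone.

Measured so far:
compound 1, `Cc1nc2ccccc2c(=O)n1NC(=O)NC1CCCCC1`, 41.9% in a functional assay on the whole organism (strain Sprague-Dawley) for inhibition, with Rattus norvegicus as the target, read by paw edema, with stated times of 30 min and 2 h, at a dose of 80 mg/kg by the oral route; a lower number here means less inhibition, a higher number more inhibition at the dose given (going by the name of the read-out)
compound 2, `O=c1c2ccccc2nc(CO[N+](=O)[O-])n1NS(=O)(=O)c1ccccc1`, 11.6% in this assay

Of these two, compound 2 stands lowest in this assay; compound 1 gives a number higher by a margin beyond the usual scatter. Compound 3, `CC(=O)Nc1ccc(S(=O)(=O)Nn2c(CO[N+](=O)[O-])nc3ccccc3c2=O)cc1`, has not yet been measured in this assay. It differs from compound 2 by acetamido in place of hydrogen on an aromatic carbon. Going by the values given here, no step between measured compounds bears on this change, so its size is open; the expectation is a small upward shift, barely beyond the scatter, estimated as a number 6.4 percentage points higher from compound 2 to compound 3 (within the scatter). Compound 3 is therefore expected to give 18%, within a range from 5% to 35%.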

Compound 3, a percentage reported as inhibition, in the whole organism at one dose (the size of the read-out at that dose, not a potency): 40.4%
For compound 3 the middle estimate is 22.4 percentage points below the measured one; the measured number lies above the stated range.
By their numbers in this assay, from the lowest: compound 2; then compounds 3 and 1 (each within the scatter of the next).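

Changing phenyl to 4-acetamidophenyl gives, in this assay, a number 28.8 percentage points higher from compound 2 to compound 3 (beyond the scatter), so this aromatic carbon, para to a large group, is a place where a substitution can change the inhibition seen at this dose. Going by these compounds alone, this is the first single-place step available, and it rests on one pair. Nothing measured here explains the rise.

On these data alone, whether the rise belongs to acetamido itself or would also come with an amine, a methoxy group or a longer acyl chain at that carbon remains open. As far as these compounds go, whether another carbon of that ring would serve equally also remains open.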